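The compounds below may be only part of what the source reports. "The series", "measured", "known", "first", "only" and "open" are said of these compounds alone.

Series measured in a functional assay on A549 cells (Homo sapiens) for antiproliferative activity, read by MTT assay, with a stated time of 72 h; a higher number here means a weaker inhibitor, a lower number a stronger inhibitor:

- compound 1 `C#Cc1cccc(Nc2ncnc3cc(OC)c(OCCCN4CCNCCNCC4)cc23)c1`: > 50000 nM (a limit)
- compound 2 `COc1cc2ncnc(Nc3cccc(C(F)(F)F)c3)c2cc1OCCCN1CCNCCNCC1`: 37300 nM
- compound 3 `COc1cc2ncnc(Nc3cccc(Cl)c3)c2cc1OCCCN1CCNCCNCC1`: > 50000 nM (a limit)

Compound 3 gives > 50000 nM, which is a limit and not a number. The same holds for compound 1, and the series sits largely at the limit of > 50000 nM in this assay, at which 2 of the 3 values shown sit. Compound 2 alone has a true number, 37300 nM.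

The next change leads to compound 4 `COc1cc2ncnc(Nc3ccc(Cl)cc3Cl)c2cc1OCCCN1CCNCCNCC1`: 2,4-dichlorophenyl in place of 3-chlorophenyl on a nitrogen on an aromatic ring. That is, 2,4-dichlorophenyl replaces 3-chlorophenyl on a nitrogen on an aromatic ring.

The closest evidence comes from the measured swaps of a single group on the same aromatic ring. These are an at least 1.3-fold lower number from compound 1 to compound 2 (0.12 log units; that floor lies within the scatter), an at least 1.3-fold higher number from compound 2 to compound 3 (0.12 log units; that floor lies within the scatter) and a step that the two limits leave unreadable from compound 1 to compound 3. The first two give only floors, and the third cannot be sized. None of them tests 2,4-dichlorophenyl directly, so they offer only weak guidance and no direction. In this assay, no step beyond the scatter is therefore expected, in either direction. The estimated step is an at least 1.1-fold lower number from compound 3 to compound 4 (0.04 log units; that floor lies within the scatter).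

Compound 2 at 37300 nM anchors the only readable part of the range, so a reading close to it remains possible. Even so, another limit is the more likely result. For compound 4 the estimate is 45000 nM, with an expected range of 20000 nM to 80000 nM.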

Compound 4, half-maximal inhibitory concentration: 44200 nM
Estimate against measurement, compound 4: 1.0-fold (0.01 log units) above; measured number inside the range.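

In this assay, compound 4 gives a true number where compound 3 gave only a limit, so 2,4-dichlorophenyl on this nitrogen supplies the second readable value in the series. The comparison with the other readable value is a 1.2-fold higher number from compound 2 to compound 4 (0.07 log units; within the scatter), so 2,4-dichlorophenyl and 3-(trifluoromethyl)phenyl cannot be told apart at this position. The other two comparisons give only floors, an at least 1.1-fold lower number from compound 3 to compound 4 (0.05 log units; that floor lies within the scatter) and an at least 1.1-fold lower number from compound 1 to compound 4 (0.05 log units; that floor lies within the scatter), so the true distance of compound 4 from compound 3 and from compound 1 remains unknown, and both of those compounds stay at a limit: the limit of > 50000 nM in this assay, at which 2 of the 4 values shown sit.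

From the compounds shown here alone, whether an amine or a carboxylic acid on this phenyl ring would give a step beyond the scatter remains open. Also open, going by these compounds, is whether a longer chain on the shared core would bring the series away from the narrow top of the measurable range, where the two readable values now sit.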